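The source may hold more compounds than are shown below. What is called first, only, known or untested is meant among the compounds shown, and "the series" means these compounds.

Measured compounds in an assay on CHO cells for displacement of a labelled ligand from 5-hydroxytryptamine receptor 7 (Homo sapiens); on this read-out higher numbers stand for weaker inhibition and lower numbers for stronger inhibition:

- compound 1 `CCC1(CCCCN2CCN(c3cccc(Cl)c3)CC2)C(=O)Nc2c(Cl)cc(Cl)cc21`: 9.46 nM
- compound 2 `CC(C)CC1(CCCCN2CCN(c3cccc(Cl)c3)CC2)C(=O)Nc2ccccc21`: 1.8 nM
- compound 3 `CCC1(CCCCN2CCN(c3cccc(Cl)c3)CC2)C(=O)Nc2ccc(Cl)cc21`: 8.27 nM

Compound 2 gives the lowest number of the three in this assay; its nearest neighbour is compound 3, which gives a higher number, and compound 1 lies furthest, also higher. Among the measured compounds shown here, the only single-point step among the measured compounds, a 1.1-fold lower number from compound 1 to compound 3 (0.06 log units; within the scatter), concerns the aromatic ring and says nothing about the saturated ring carbon.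

Compound 4 `O=C1Nc2ccccc2C1CCCCN1CCN(c2cccc(Cl)c2)CC1` differs from compound 2 in one place: hydrogen in place of isobutyl on a saturated ring carbon. For the measured compounds named here, no measured step bears directly on this change. Compounds 1 and 3 carry ethyl where compound 2 carries isobutyl, and both give higher numbers than compound 2, but each also differs from compound 2 in aromatic chloro, so the two changes cannot be separated. Taking the direction from compound 2 to compounds 1 and 3 as a loose guide, a step towards a higher number in this assay is expected for compound 4, estimated at a 6.7-fold higher number from compound 2 to compound 4 (0.82 log units; beyond the scatter). Compound 4 is therefore expected to give about 12 nM, within a range of 3 nM to 45 nM.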

Compound 4, inhibition constant: 0.49 nM
Compound 4: the middle estimate sits 24-fold (1.39 log units) above what was measured, outside the stated range (below it).
By their numbers in this assay, from the lowest: compound 4; then compound 2; then compounds 3 and 1 (each within the scatter of the next).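

In this assay, among the compounds shown here, hydrogen in place of isobutyl on the saturated ring carbon gives a 3.7-fold lower number from compound 2 to compound 4 (0.57 log units; beyond the scatter) and is the only direct reading at this position. A low number on this read-out therefore does not depend on the isobutyl group, and the carbon without any alkyl group gives the lowest number of the compounds shown. No measurement on hand accounts for this step.

Going by these compounds, how ethyl on this carbon compares with hydrogen and isobutyl on a core free of aromatic chloro stays open, as compound 1 and compound 3 both carry aromatic chloro as well as ethyl. Also open, on these data alone, is whether methyl, a hydroxyl group or an amine on this carbon would keep the number near that of compound 4.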